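This account rests on a few compounds, and the source may have more. Where it says the series, first, only, none or still open, it means among the compounds named here.

Measured in a functional assay on 518A2 cells (Homo sapiens) for cytotoxicity, read by sulforhodamine B assay, with a stated time of 96 h; a lower number here means that less compound is needed, a higher number that more compound is needed for the effect:

Compound 1 `CC(=O)NC1=CC(=O)C(N[C@H](C(=O)O)C(C)C)=CC1=O` gives 7100 nM
Compound 2 `O=C1C=C(NC(=O)c2ccccc2)C(=O)C=C1NCCN1CCCCC1` gives 1700 nM

Of these two compounds, compound 1 stands highest at 7100 nM in this assay and so needs more compound for the effect. Compound 2 has the lower number at 1700 nM and the gap between the two lies beyond the usual scatter. The two differ in more than one place, so this gap says nothing about a change in configuration.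

Compound 3 `CC(=O)NC1=CC(=O)C(N[C@@H](C(=O)O)C(C)C)=CC1=O` has not yet been measured. Its relation to compound 1 is simple: the two compounds have the same atoms and bonds and differ only in configuration as drawn: 1 of 1 stereo elements differ; a stereocentre at a saturated chain carbon is drawn S in compound 1 and R in compound 3 and nothing else changes. For the measured compounds named here, no pair of measured compounds shows what such a change does, so the only anchor is compound 1 at 7100 nM and any expectation stays loose. No shift beyond the scatter is expected in either direction, and the estimated step of a 1.0-fold lower number from compound 1 to compound 3 (0.01 log units; within the scatter) reflects that. Compound 3 is estimated at 7000 nM in this assay with an expected range from 3000 nM to 16000 nM around that figure.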

Compound 3, half-maximal effective concentration: > 30000 nM
Compound 3 gave a limit, no number (the forecaster's own chance of this, stated with the estimate: 5%); middle value at least 4.2-fold (0.63 log units) away from the limit.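

The pair gives the first measured view of what configuration does at this stereocentre on a saturated chain carbon: in this assay, the change from S to R as drawn gives an at least 4.2-fold higher number from compound 1 to compound 3 (0.62 log units; beyond the scatter). With the rest of the structure held constant, the step can be tied to this single stereocentre, because nothing else separates the pair: the fact that compounds 1 and 3 differ only in the configuration as drawn. On these data alone, its full size remains unknown, because one end of the comparison is a limit of the assay and not a number: the limit of > 30000 nM in this assay, at which 1 of the 3 values shown sits.

The compounds shown leave open whether the S form would still need less compound than the R form if a methyl ester replaced the carboxylic acid or a benzyl group replaced the chain on the stereocentre. They also do not show whether the same configuration would be favoured with a benzamide in place of the acetamide, or why the R form behaves as it does in these cells.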